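From Cyclohexyl to Oxolan-3-yl on an Amide-Type Nitrogen

The compounds below may be only part of what the source reports. "The series", "measured", "known", "first", "only" and "open" are said of these compounds alone.

In a physicochemical assay for solubility, read by chemiluminescence (a higher number here means a more soluble compound, a lower number a less soluble compound), compound 1 (`O=C(CN(C(=O)c1ccc(N2CCCC2)cc1)C1CCCCC1)Nc1cc(F)cc(F)c1`) gives 5 ug/mL and compound 2 (`O=C(CN(C(=O)c1ccc(-c2ccccn2)cc1)C1CCCCC1)Nc1cc(F)cc(F)c1`) gives 6 ug/mL so the two stand level. Among the compounds with values here, they form the only measured step, a 1.2-fold higher number from compound 1 to compound 2 (0.08 log units; within the scatter) and that step lies on an aromatic carbon. Within the data shown here, compound 3 (`COc1ccc(C(=O)N(Cc2c[nH]c(-c3ccccc3)n2)C2CCCCC2)cc1`) gives 20 ug/mL which is higher than the number for compound 2 by more than the scatter, but it does not share the core of compound 2 and forms no step with it.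

Compound 4 (`O=C(CN(C(=O)c1ccc(-c2ccccn2)cc1)C1CCOC1)Nc1cc(F)cc(F)c1`) carries oxolan-3-yl in place of cyclohexyl on an amide-type nitrogen and is otherwise the same as compound 2. Among the measured compounds shown here, no measured step touches that nitrogen, so the data offer no direct guide to the size of this change. The expected change is a 2.3-fold higher number from compound 2 to compound 4 (0.37 log units; beyond the scatter) and this estimate rests on the structural change alone. Compound 4 is therefore estimated at 14 ug/mL with an expected range from 6 ug/mL to 35 ug/mL in this assay once it is measured.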

Compound 4, solubility: 102 ug/mL
The estimate for compound 4 lay 7.3-fold (0.86 log units) below the measured number; the measured number lies above the stated range.
By their numbers in this assay, from the lowest: compounds 1 and 2 (each within the scatter of the next); then compound 3; then compound 4.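

In this assay, the exchange of cyclohexyl for oxolan-3-yl on an amide-type nitrogen gives a 17-fold higher number from compound 2 to compound 4 (1.23 log units; beyond the scatter) and is the first step shown that lies beyond the scatter. Within the data shown here, the only earlier step, a 1.2-fold higher number from compound 1 to compound 2 (0.08 log units; within the scatter) on an aromatic carbon, left the two numbers level, so this nitrogen is the first place where a single exchange clearly moves the number. The exchange replaces a six-membered ring of carbon only with a five-membered ring with 1 hetero atom, and nothing available here explains the size of the step.

From the compounds shown here alone, it remains open whether cyclopentyl on this nitrogen would stay close to compound 2 or approach compound 4. Also open, going by these compounds, is whether oxolan-3-yl would give a similar step with pyrrolidin-1-yl on the aromatic carbon, as in compound 1.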